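Replacing the 2-chlorophenyl group of compound 2

The source may hold more compounds than are shown below. What is called first, only, known or untested is meant among the compounds shown, and "the series" means these compounds.

Going by the values given here, in a functional assay on HL-60 cells (Homo sapiens) for inhibition, read by MTT assay, with a stated time of 72 h (on this read-out higher numbers stand for weaker inhibition and lower numbers for stronger inhibition), compound 2 `Cc1nc(-c2ccccc2Cl)c(C(=O)N2CCN(c3cccc(Cl)c3)CC2)o1` gives 132 nM, the only number among the measured compounds. Compound 1 `COc1ccc(-c2nc(C)oc2C(=O)N2CCN(c3cccc(Cl)c3)CC2)cc1OC` is reported as "not active" (no number reported). Compound 3 `Cc1ccc(C)c(N2CCN(C(=O)c3oc(C)nc3-c3ccccc3Cl)CC2)c1` is recorded at > 1000 nM, which is a limit and not a number. Among the compounds with values here, the one measured step, an at least 7.5-fold higher number from compound 2 to compound 3 (0.87 log units; beyond the scatter), lies beyond the scatter but concerns the other end of the molecule. Compound 4 `COc1cc(-c2nc(C)oc2C(=O)N2CCN(c3cccc(Cl)c3)CC2)ccc1O` carries 4-hydroxy-3-methoxyphenyl in place of 2-chlorophenyl on an aromatic carbon. Within the data shown here, no measured step covers this place, so the expectation leans on that upward step and on compound 1 at "not active" (no number reported). The expected change is a 5.3-fold higher number from compound 2 to compound 4 (0.72 log units; beyond the scatter), towards weaker inhibition, beyond the scatter. For compound 4 the estimated value is 700 nM, with an expected range from 150 nM to 3000 nM.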

Compound 4, half-maximal inhibitory concentration: 85.9 nM
Beside the measured number, compound 4's estimate is 8.1-fold (0.91 log units) above it, outside the stated range (below it).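

In this assay the exchange at this position is a 1.5-fold lower number from compound 2 to compound 4 (0.19 log units; within the scatter) so the larger 4-hydroxy-3-methoxyphenyl, with its hydrogen-bond donor and acceptors, stands in for 2-chlorophenyl without a change that can be told from scatter. With a methoxy group in place of the hydroxy group of 4-hydroxy-3-methoxyphenyl, compound 1 is recorded as "not active" (no number reported) whereas compound 4 gives 85.9 nM in the same assay. The compounds shown leave open whether an amine or a carboxylic acid in place of that hydroxy group would keep this level of inhibition. Nothing given here accounts for the contrast between these compounds.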